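Methyl for methoxy on a lactone series, second instance

This account rests on a few compounds, and the source may have more. Where it says the series, first, only, none or still open, it means among the compounds named here.

Measured so far:
compound 1, `COc1ccccc1C[C@H]1C(=O)OC[C@@H]1Cc1ccccc1`, 79000 nM
compound 2, `Cc1ccccc1C[C@H]1C(=O)OC[C@@H]1Cc1ccccc1`, 57000 nM
compound 3, `COc1ccc(C[C@H]2COC(=O)[C@@H]2Cc2ccc(Cl)c(Cl)c2)cc1`, 37000 nM

The three compounds were tested in a functional assay on HL-60 cells (Homo sapiens) for cytotoxicity, read by WST assay, with a stated time of 48 h; a higher number here means that more compound is needed for the effect, a lower number that less compound is needed. Compound 1 gives 79000 nM there, and compound 2 gives 57000 nM; the change between them is methyl in place of methoxy on an aromatic carbon, and the step is a 1.4-fold lower number from compound 1 to compound 2 (0.14 log units; within the scatter). Compound 3, which gives 37000 nM in this assay, has a core whose difference from that of compound 1 is not broken down here. Compound 4, `Cc1ccc(C[C@H]2COC(=O)[C@@H]2Cc2ccc(Cl)c(Cl)c2)cc1`, carries the same kind of change as compound 2: methyl in place of methoxy on an aromatic carbon. The place differs, though: in compound 2 the new group sits ortho to a large group, in compound 4 para to a large group. Because the step of a 1.4-fold lower number from compound 1 to compound 2 (0.14 log units; within the scatter) stayed within the scatter, the step from compound 3 to compound 4 is expected to be small, about a 1.2-fold lower number from compound 3 to compound 4 (0.09 log units; within the scatter). The estimate for compound 4 in this assay is 30000 nM, between 12000 nM and 75000 nM.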

Compound 4, half-maximal effective concentration: 19000 nM
Compound 4: middle estimate off by 1.6-fold (0.20 log units), on the high side; measured number inside the range.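

In this assay the new step is a 1.9-fold lower number from compound 3 to compound 4 (0.29 log units; within the scatter), the second instance of methyl in place of methoxy on an aromatic carbon. Set beside the first instance, it shows that the change carried from one core to the other without a difference that can be told from the scatter: the same change on two cores in this assay, a 1.4-fold lower number (0.14 log units; within the scatter) from compound 1 to compound 2 and a 1.9-fold lower number (0.29 log units; within the scatter) from compound 3 to compound 4, 1.4-fold (0.15 log units) apart, within the scatter of two such steps. It does not show a real difference between methyl and methoxy on either core, as each step alone lies within the scatter, and two cores set no rule for the whole series.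

The compounds shown leave open whether another group at this place, such as an amine, a carboxylic acid or a longer chain, would give a step beyond the scatter. They also leave open whether the place on the ring matters apart from the core, as the two steps differ in both.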